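Aryl swap on the shared core: canine microsomal half-life

The source may hold more compounds than are shown below. What is called first, only, known or untested is meant among the compounds shown, and "the series" means these compounds.

Compound 1 `Nc1nc(NCCNc2ncc(-c3ncc[nH]3)c(-c3ccc(C(F)(F)F)cc3)n2)ccc1[N+](=O)[O-]` is the reference point. In an ADME assay on microsomes from liver (Canis lupus familiaris) for metabolic stability (on this read-out lower numbers stand for a shorter-lived compound and higher numbers for a longer-lived compound), compound 1 gives > 0.5 h, which is a limit of the assay and not a number. Compound 2 `Nc1nc(NCCNc2ncc(-c3ncc[nH]3)c(-c3cc(F)ccc3Cl)n2)ccc1[N+](=O)[O-]` is measured at > 0.5 h, again a limit. Compound 3 `Nc1nc(NCCNc2ncc(-c3ncc[nH]3)c(-c3ccc(Br)cc3F)n2)ccc1[N+](=O)[O-]` sits at > 0.5 h, also a limit. Accordingly the measured steps cannot be read: a step that the two limits leave unreadable from compound 1 to compound 2, a step that the two limits leave unreadable from compound 1 to compound 3 and a step that the two limits leave unreadable from compound 2 to compound 3; all three values rest at the limit of > 0.5 h in this assay, at which 3 of the 3 values shown sit.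

Compound 4 `Nc1nc(NCCNc2ncc(-c3ncc[nH]3)c(-c3ccc(Br)cc3Cl)n2)ccc1[N+](=O)[O-]` is not yet measured. It differs from compound 1 by 4-bromo-2-chlorophenyl in place of 4-(trifluoromethyl)phenyl on an aromatic carbon.

The two measured steps starting from compound 1 bear on this change, yet neither has a readable size. Because the limit of > 0.5 h in this assay, at which 3 of the 3 values shown sit, covers every value shown, no shift in this assay beyond the scatter is expected, and the step that the limit leaves unreadable from compound 1 to compound 4 is an estimate resting on limits alone. Compound 4 is expected to give 1 h, within 0.5 h to 3 h, and most probably to be reported only as a limit.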

Compound 4, half-life: > 0.5 h
Compound 4: only a limit was reported; the forecaster's own chance of this, stated with the estimate: 85%; the middle value does not contradict the limit.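

Compound 4 also gives a limit and not a number, so its steps from compound 1, compound 2 and compound 3 cannot be read: the limit of > 0.5 h in this assay, at which 4 of the 4 values shown sit.

The compounds shown leave open where each of them truly lies in this assay, and whether any aryl group on the shared core would separate them.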